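A few compounds are considered here, and "the series" means these few. Any claim that something is new, unique, unknown or untested is made for them only; others in the source may bear on it.

Compound 1, `Cc1ccc(S(=O)(=O)Oc2ccc3c(c2C)[C@H](Cn2cc(-c4ccccc4)nn2)[C@@]24CC(=O)[C@@](C)(CC[C@@H]32)C4)cc1`: in a functional assay on A549 cells (Homo sapiens) for cytotoxicity, read by MTT assay, with a stated time of 4 days (a lower number here means a stronger inhibitor, a higher number a weaker inhibitor), compound 1 gives only a limit of the assay, > 20000 nM.
Compound 2, `Cc1ccc(S(=O)(=O)Oc2ccc3c(c2C)[C@H](Cn2cc(-c4ccc(Br)cc4)nn2)[C@@]24CC(=O)[C@@](C)(CC[C@@H]32)C4)cc1`: in this assay compound 2 likewise gives only a limit, > 20000 nM.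
Compound 3, `Cc1ccc(-c2cn(C[C@H]3c4c(ccc(O)c4C)[C@@H]4CC[C@@]5(C)C[C@]43CC5=O)nn2)cc1`: in this assay compound 3 also gives only a limit, > 20000 nM.

Compound 3 therefore stands at the limit, and it shares that position with every other value shown, since (the limit of > 20000 nM in this assay, at which 3 of the 3 values shown sit). Going by the values given here, the one pair that differs in a single place, compound 1 and compound 2, gives a step that the two limits leave unreadable from compound 1 to compound 2 whose size cannot be read, both values being limits.

Compound 4, `Cc1ccc(-c2cn(C[C@H]3c4c(ccc(OS(=O)(=O)c5ccc(C)cc5)c4C)[C@@H]4CC[C@@]5(C)C[C@]43CC5=O)nn2)cc1`, differs from compound 3 in one place: (4-methylphenyl)sulfonyl in place of hydrogen on an oxygen on an aromatic ring. Among the compounds with values here, no measured step isolates this change. What can be said is that compound 1 and compound 2 already carry the (4-methylphenyl)sulfonyl group on the aromatic oxygen and both sit at the limit, while compound 3, with the free hydroxy, sits at the limit as well. On that evidence no step beyond the scatter is expected from compound 3 to compound 4 in this assay, so a step that the limit leaves unreadable from compound 3 to compound 4 is the estimated step. Compound 4 is thus expected to return a limit again, with an estimated value of 30000 nM in a range from 15000 nM to 80000 nM.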

Compound 4, half-maximal inhibitory concentration: > 20000 nM
Compound 4: a limit, no number; the forecaster's own chance of this, stated with the estimate: 90%; the middle value is on the limit's open side.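

In this assay compound 4 also gives only a limit, so none of its steps from compound 1, compound 2 or compound 3 can be read, and all four compounds end at the same limit: the limit of > 20000 nM in this assay, at which 4 of the 4 values shown sit.

The compounds shown leave open how strongly any of them acts in this assay, and whether any change on the shared core would give a readable number.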